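A few compounds are considered here, and "the series" means these few. Any claim that something is new, unique, unknown or untested is made for them only; others in the source may bear on it.

Working notes on the hydrazone series. In an ADME assay on WI-38 cells (Homo sapiens) for cytotoxicity, read by colorimetric assay and crystal violet staining, with a stated time of 24 h (on this read-out lower numbers stand for stronger inhibition and higher numbers for weaker inhibition), compound 1 `COc1ccc(OC)c(/C=N/NC(=O)c2ccc(-c3cccc(Cl)c3)nc2C)c1` gives 188 ug/mL, compound 2 `COc1ccc(/C=N/NC(=O)c2ccc(-c3cccc(Cl)c3)nc2C)cc1` gives 500 ug/mL, and compound 3 `COc1cc(/C=N/NC(=O)c2ccc(-c3ccc(Cl)cc3)nc2C)cc(OC)c1OC` gives 41.1 ug/mL. Compound 2 thus stands highest of the three in this assay, with compound 1 nearest and compound 3 furthest from it. Compound 4 `COc1ccc(/C=N/NC(=O)c2ccc(-c3cccc(Cl)c3)nc2C)cc1OC` is the next member; it differs from compound 2 by methoxy in place of hydrogen on an aromatic carbon, placed ortho to a methoxy group and meta to a large group. Since compound 1, which also carries two methoxy groups, gives 188 ug/mL, a step toward a lower number in this assay is expected, of the order of a 2.5-fold lower number from compound 2 to compound 4 (0.40 log units; beyond the scatter). Compound 4 is therefore estimated at 200 ug/mL in this assay, within 80 ug/mL to 500 ug/mL.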

Compound 4, half-maximal inhibitory concentration: 168 ug/mL
For compound 4 the middle estimate is 1.2-fold (0.08 log units) above the measured one; the range from low to high includes it.
By their numbers in this assay, from the lowest: compound 3; then compounds 4 and 1 (each within the scatter of the next); then compound 2.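

In this assay, among the compounds shown here, methoxy in place of hydrogen on an aromatic carbon, ortho to a methoxy group and meta to a large group, gives a 3.0-fold lower number from compound 2 to compound 4 (0.47 log units; beyond the scatter) and so provides the first step between compounds differing in one place. This position therefore responds to substitution, at least to methoxy. Nothing shown gives a reason for the step. As far as these compounds go, whether an amine or a carboxylic acid at this place would move the number the same way remains open, as does whether the step carries over to the core of compound 3.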